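The source may report more compounds than this note shows. Statements on the series, on what has been measured and on what is new or still open speak of the compounds shown alone.

Of the compounds shown here, three have been read in a functional assay on Malme-3M cells (Homo sapiens) for inhibition, read by sulforhodamine B assay, with a stated time of 48 h; a higher number here means a weaker inhibitor of growth, a lower number a stronger inhibitor of growth. Compound 1 `COc1cc(-c2nn(-c3cccc(NC(=O)c4cccc(C(F)(F)F)c4)c3)cc2-c2ccncc2)ccc1Cl` gives 1990 nM. Compound 2 `COc1cc(-c2nn(-c3cccc(NC(=O)Nc4ccc(Cl)c(Cl)c4)c3)cc2-c2ccncc2)ccc1Cl` gives 926 nM, and compound 3 `COc1cc(-c2nn(-c3cccc(NC(=O)Nc4ccc(Cl)c(C(F)(F)F)c4)c3)cc2-c2ccncc2)ccc1Cl` gives 838 nM. Compound 3 thus carries the lowest of the three numbers, but its gap to compound 2, a 1.1-fold lower number from compound 2 to compound 3 (0.04 log units; within the scatter), is within the scatter, so those two cannot be ordered; only the gap to compound 1 is resolved. Compound 4 `COc1cc(-c2nn(-c3cccc(NC(=O)c4ccccc4)c3)cc2-c2ccncc2)ccc1Cl` has not yet been measured. Relative to compound 3 the change is phenyl in place of (4-chloro-3-(trifluoromethyl)phenyl)amino on a carbonyl carbon. Among the compounds with values here, two measured steps bear on this, and both run in the opposite direction: a 2.4-fold lower number from compound 1 to compound 3 (0.38 log units; beyond the scatter) and a 2.1-fold lower number from compound 1 to compound 2 (0.33 log units; beyond the scatter), each a modest move to a lower number on exchanging the group on the carbonyl carbon of compound 1. Undoing the first of these would return compound 4 to the region of compound 1, and compound 4 further lacks the trifluoromethyl present in compound 1, a change for which no step has been measured. The expectation in this assay is therefore a modest step to a higher number, a 4.2-fold higher number from compound 3 to compound 4 (0.62 log units; beyond the scatter). Compound 4 is estimated at 3500 nM, with a range from 1500 nM to 8000 nM.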

Compound 4, concentration for 50% growth inhibition: 537 nM
The estimate for compound 4 lay 6.5-fold (0.81 log units) above the measured number; measured number outside the range, below it.
By their numbers in this assay, from the lowest: compounds 4, 3 and 2 (each within the scatter of the next); then compound 1.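

In this assay, phenyl on the carbonyl carbon stands level with both larger amino-linked aryl groups: a 1.6-fold lower number from compound 3 to compound 4 (0.19 log units; within the scatter), and a 1.7-fold lower number from compound 2 to compound 4 (0.24 log units; within the scatter). The (4-chloro-3-(trifluoromethyl)phenyl)amino and (3,4-dichlorophenyl)amino groups, each with its hydrogen-bond donor and halogen substituents, are therefore not needed at this place to reach this range of numbers, and the smaller, unsubstituted phenyl serves there without a resolved loss. The new resolved step is a different one, hydrogen in place of trifluoromethyl on an aromatic carbon: a 3.7-fold lower number from compound 1 to compound 4 (0.57 log units; beyond the scatter), which leaves compound 1 apart from the other three and shows that the trifluoromethyl on its phenyl ring, and not only the absence of an amino link, separates it from this group. No available evidence explains these numbers.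

Open, on these data alone, is how a morpholine, a pyridine ring, a short alkyl chain or a carboxylic acid on the carbonyl carbon would compare with phenyl. Also open, as far as these compounds go, is whether a lone chloro or methoxy on that phenyl would give a step like the one seen with trifluoromethyl.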